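Acylating the Amine of Compound 2

The source may report more compounds than this note shows. Statements on the series, on what has been measured and on what is new or still open speak of the compounds shown alone.

Compound 2 `CC(C)C[C@H](N)c1cc(C(F)(F)F)ccc1N1CCN(C(=O)C2C(=O)OCC2c2ccc(Cl)cc2)CC1` is one of three compounds compared in an assay on HEK293 cells for displacement of a labelled ligand from Melanocortin receptor 4 (Homo sapiens); on this read-out lower numbers stand for stronger inhibition and higher numbers for weaker inhibition. Compound 2 gives 260 nM, the highest of the three numbers. Compound 3 `CNCCC(=O)N[C@@H](CC(C)C)c1cc(C(F)(F)F)ccc1N1CCN(C(=O)[C@H]2CS(=O)(=O)C[C@@H]2c2ccc(Cl)cc2)CC1` gives 190 nM, which lies within the scatter of compound 2. Compound 1 `CC(C)C[C@H](N)c1cc(C(F)(F)F)ccc1N1CCN(C(=O)[C@H]2CS(=O)(=O)C[C@@H]2c2ccc(Cl)cc2)CC1` gives 38 nM, well below compound 2. Compound 4 `CC(C)C[C@H](NC(=O)CCN(C)C)c1cc(C(F)(F)F)ccc1N1CCN(C(=O)C2C(=O)OCC2c2ccc(Cl)cc2)CC1` has not yet been measured; it differs from compound 2 in one place: (2-(dimethylamino)ethyl)carbonyl in place of hydrogen on an amine nitrogen. Going by the values given here, the only measured step that bears on this change is a 5.0-fold higher number from compound 1 to compound 3 (0.70 log units; beyond the scatter), where a closely related acyl group replaced hydrogen on the same kind of amine nitrogen and the number rose beyond the scatter. For compound 4 the entering group is (2-(dimethylamino)ethyl)carbonyl rather than the (2-(methylamino)ethyl)carbonyl of compound 3, and the core is that of compound 2, so the size is less certain, but the direction is expected to match. Compound 4 is therefore expected to show a 3.8-fold higher number from compound 2 to compound 4 (0.59 log units; beyond the scatter). The estimate for compound 4 is 1000 nM, with a range from 350 nM to 3000 nM.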

Compound 4, inhibition constant: 290 nM
Estimate against measurement, compound 4: 3.4-fold (0.54 log units) above; the measured number lies below the stated range.
By their numbers in this assay, from the lowest: compound 1; then compounds 3, 2 and 4 (each within the scatter of the next).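

Replacing hydrogen on the amine nitrogen with (2-(dimethylamino)ethyl)carbonyl gives a 1.1-fold higher number from compound 2 to compound 4 (0.05 log units; within the scatter) in this assay, so acylation at this position does not always move the number beyond the scatter. The earlier step, a 5.0-fold higher number from compound 1 to compound 3 (0.70 log units; beyond the scatter), did go beyond the scatter, but it involved a different core and a closely related acyl group, so the two steps differ in both respects. Nothing available here gives a reason for this contrast.

The compounds shown leave open whether the core or the entering group separates the two steps, a question that (2-(dimethylamino)ethyl)carbonyl on the core of compound 1 could address. They also leave open how an acetyl group, which has no amine in its chain, or a longer chain ending in a dimethylamino group would read at this nitrogen.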